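This account rests on a few compounds, and the source may have more. Where it says the series, first, only, none or still open, it means among the compounds named here.

Measured compounds:
Compound 1 `COc1cc(/C=C/C(=O)c2sc(Nc3ccccc3C)nc2C)cc(OC)c1OC` gives 10300 nM in a functional assay on Bel-7402 cells (Homo sapiens) for cytotoxicity, read by MTT assay; a higher number here means a weaker inhibitor, a lower number a stronger inhibitor.
Compound 2 `COc1ccc(/C=C/C(=O)c2sc(Nc3ccc(Cl)c(Cl)c3)nc2C)cc1` gives > 25000 nM in this assay, which is a limit of the assay and not a number.
Compound 3 `Cc1nc(Nc2ccccc2)sc1C(=O)/C=C/c1ccccc1` gives > 25000 nM in this assay, again a limit of the assay rather than a number.

Among the three, compound 1 stands alone as the only compound with a numerical reading; the other two rest at the limit of > 25000 nM in this assay, at which 2 of the 3 values shown sit. Going by the values given here, compound 1 is thus the only anchor for judging any change on its aniline ring, and no step between two measured compounds is available for comparison.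

The unmeasured compound 4 `COc1cc(/C=C/C(=O)c2sc(Nc3ccccc3)nc2C)cc(OC)c1OC` differs from compound 1 in one place: hydrogen in place of methyl on an aromatic carbon. The rest of the molecule, including the trimethoxy-substituted side, is kept unchanged.

Compound 3 carries the plain anilino group that compound 4 also has, but it sits at a limit and lacks the methoxy groups, so it gives no direct guide. Given how little the change removes, the step expected from compound 1 to compound 4 is a 1.5-fold higher number from compound 1 to compound 4 (0.16 log units; within the scatter), modest and within or just beyond the scatter, leaning toward weaker inhibition. Compound 4 is therefore estimated at 15000 nM, with a range from 5000 nM to 40000 nM, and a real chance that only a limit is reported.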

Compound 4, half-maximal inhibitory concentration: > 25000 nM
Compound 4: no number, only a limit; the forecaster's own chance of this, stated with the estimate: 35%; middle value at least 1.6-fold (0.22 log units) away from the limit.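

Going by these compounds alone, the change of 2-methylphenyl to phenyl gives an at least 2.4-fold higher number from compound 1 to compound 4 (0.38 log units; beyond the scatter) in this assay, the first step in this set that can be read at this position. Going by these compounds, compound 4 gives > 25000 nM, which is a limit of the assay and not a number, so the step marks only a lower bound and its full size stays unknown. With the rest of the molecule unchanged, this single methyl, on an aromatic carbon ortho to a large group, separates the only numerical reading in the set from a reading at the limit: the limit of > 25000 nM in this assay, at which 3 of the 4 values shown sit.

The compounds shown leave open whether another group in the same place, such as an ethyl group, a fluorine atom or a hydroxyl group, would keep a numerical reading, or would move it in either direction from that of compound 1. Within the data shown here, they also leave open whether the methyl would have a similar effect on a molecule without the trimethoxy-substituted side, since no measured pair isolates that question.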